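This account rests on a few compounds, and the source may have more. Where it says the series, first, only, none or still open, it means among the compounds named here.

Compound 1 `Cc1ccc(/C=C2\CCC/C(=C\c3cccc([N+](=O)[O-])c3)C2=O)cc1` is one of two measured compounds in this study. In a physicochemical assay for lipophilicity (a higher number here means a more lipophilic compound, a lower number a more polar compound), compound 1 gives 5.06. Compound 2 `COc1cc(/C=C2\CCC/C(=C\c3cccc([N+](=O)[O-])c3)C2=O)cc(OC)c1OC` carries a differently substituted aryl ring on the other side of the shared core; in this assay compound 2 gives 5.06. Compound 1 thus stands level with compound 2 at the digits reported, the two values lying within the scatter of one another.

Compound 3 `O=C1/C(=C/c2ccc(Cl)cc2)CCC/C1=C\c1cccc([N+](=O)[O-])c1` has not yet been measured in this assay. It differs from compound 1 by chloro in place of methyl on an aromatic carbon. Among the compounds with values here, no step between measured compounds of this kind is available here to guide the expectation. The swap of one heavy atom for another at the same place is expected to shift this assay only slightly upward, if at all, by an estimated a number 0.14 log units higher from compound 1 to compound 3 (within the scatter), which would not clearly exceed the scatter. Compound 3 is therefore estimated at 5.2, with a range from 4.9 to 5.5.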

Compound 3, partition coefficient: 5.06
The estimate for compound 3 lay 0.14 log units above the measured number; low and high end bracket the measured number.
By their numbers in this assay, from the lowest: compounds 1, 2 and 3 (each within the scatter of the next).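

In this assay, chloro in place of methyl on an aromatic carbon, para to a large group, gives no change at the digits printed from compound 1 to compound 3 (within the scatter). This is the only step in the compounds shown that isolates a single change, so it offers the first direct reading at this place: 4-methylphenyl and 4-chlorophenyl cannot be told apart in this measurement. No supporting data bear on why the two groups read alike.

Within the data shown here, whether the same place would tolerate an amine, a carboxylic acid or a longer chain with as little movement remains open, since methyl and chloro are the only two groups compared here in a single step. From the compounds shown here alone, it is also open whether the same exchange of methyl for chloro would read alike at another place on the aromatic ring.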